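Cyclopropyl for methyl on the piperazine nitrogen of compound 1

The compounds below may be only part of what the source reports. "The series", "measured", "known", "first", "only" and "open" are said of these compounds alone.

Compound 1, `CN1CCN(CCCN(C[C@H]2Cc3ccccc3CN2)[C@H]2CCCc3cccnc32)CC1`, is the starting point of this step. In an ADME assay on microsomes from liver (Rattus norvegicus) for metabolic stability, read by LC-MS, with a stated time of 10 min, tested at 0.5 uM (on this read-out lower numbers stand for a less stable compound and higher numbers for a more stable compound), compound 1 gives 10%, the lowest of the two numbers measured here. Among the compounds with values here, the only other measured compound, compound 2 with the structure `c1cnc2c(c1)CCC[C@@H]2N(CCCN1CCNCC1)Cc1nc2ccccc2s1`, gives 21% in this assay, a number that stands higher than that of compound 1 by more than the usual scatter. Compound 2 differs from compound 1 in more than one place, so its number says nothing direct about any single change.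

The new compound 3, `c1ccc2c(c1)CN[C@@H](CN(CCCN1CCN(C3CC3)CC1)[C@H]1CCCc3cccnc31)C2`, keeps the core of compound 1 and differs from it in one place: cyclopropyl in place of methyl on an amine nitrogen in a ring. Within the data shown here, no pair of measured compounds shows this change, so its effect on the read-out is unknown from the data at hand. Compound 1 sits low in this assay, which leaves little room downward and more room upward.

The step of a number 8 percentage points higher from compound 1 to compound 3 (within the scatter) is expected to be small and upward, possibly not beyond the scatter. For compound 3 the estimate in this assay is 18%, with a range from 5% to 40%.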

Compound 3, percent of the compound remaining: 2%
The estimate for compound 3 lay 16 percentage points above the measured number; measured number outside the range, below it.
By their numbers in this assay, from the lowest: compounds 3 and 1 (each within the scatter of the next); then compound 2.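

In this assay, within the data shown here, cyclopropyl in place of methyl on the amine nitrogen in the ring gives a number 8 percentage points lower from compound 1 to compound 3 (within the scatter) and so provides the first reading of a single change at this position. On this read-out, compound 1 and compound 3 cannot be told apart, which means that going from 4-methylpiperazin-1-yl to 4-cyclopropylpiperazin-1-yl shows no effect that can be separated from the usual scatter. This holds for this one pair on the core of compound 1 and sets no rule for other groups at this nitrogen, and no measurement at hand offers an explanation for the result. The compounds shown leave open whether a different group on this nitrogen, such as an acetyl group or a longer chain like 2-hydroxyethyl, would move the number beyond the scatter. They also leave open whether the exchange of methyl for cyclopropyl would read the same way on another core, since this single pair is the only one that shows it.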